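Replacing a long side chain with a short one

The source may report more compounds than this note shows. Statements on the series, on what has been measured and on what is new or still open speak of the compounds shown alone.

Three compounds share a core built around a purine-like ring carrying a cyclopropyl group and an amide-linked amino-acid ester, and all were tested in a functional assay on the whole organism (Tail, strain ICR) with Mus musculus as the target, in the tail flick test, with a stated time of 150 min, at a dose of 25 umol/kg by the oral route; a higher number here means a stronger effect of the compound at the dose given, a lower number a weaker effect. Compound 1 `N=C(N)NCCC[C@H](NC(=O)CN(c1ncnc2c1ncn2C1CCCCO1)C1CC1)C(=O)OCc1ccccc1` gives 19.6%. Compound 3 `NC(=O)C[C@H](NC(=O)CN(c1nc(Cl)nc2[nH]cnc12)C1CC1)C(=O)OCc1ccccc1` gives 13.5%, and compound 2 `O=C(CN(c1nc(Cl)nc2[nH]cnc12)C1CC1)N[C@@H](CC(=O)OCc1ccccc1)C(=O)OCc1ccccc1` gives 6.68%. Compound 1 holds the highest of the three numbers, yet its gap to compound 3 lies within the scatter, so those two cannot be separated; only compound 2 falls clearly beyond the scatter from compound 1.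

Among the measured compounds shown here, the one measured step, a number 6.8 percentage points higher from compound 2 to compound 3 (within the scatter), changed the ester end of the side chain and produced no shift beyond the scatter.

Compound 4 `C[C@@H](O)[C@H](NC(=O)CN(c1ncnc2c1ncn2C1CCCCO1)C1CC1)C(=O)OCc1ccccc1` differs from compound 1 by a group of 3 heavy atoms (2 carbon, 1 oxygen; no ring) in place of a group of 7 heavy atoms (4 carbon, 3 nitrogen; no ring), on a saturated chain carbon bound to an amide-type nitrogen and a carbonyl carbon. Nothing measured here changes the side chain at that place, so the step from compound 2 to compound 3 bears only loosely, and its small size suggests that side-chain changes in this series are not dramatic. A modest fall or no change beyond the scatter is therefore expected, a number 7.6 percentage points lower from compound 1 to compound 4 (within the scatter), since the group that leaves is far larger than the one that enters. Compound 4 is estimated to give 12%, within a range from 3% to 22%.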

Compound 4, a percentage reported as activity, at one dose (the size of the read-out at that dose, not a potency): 6.53%
Compound 4: the middle estimate sits 5.5 percentage points above what was measured; low and high end bracket the measured number.
By their numbers in this assay, from the lowest: compounds 4, 2, 3 and 1 (each within the scatter of the next, the first and the last beyond it).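

On the saturated chain carbon bound to an amide-type nitrogen and a carbonyl carbon, the side chain clearly counts in this assay: putting 1-hydroxyethyl in place of the group of 7 heavy atoms gives a number 13.1 percentage points lower from compound 1 to compound 4 (beyond the scatter) and so moves the read-out beyond the scatter. The only earlier step between measured compounds, a number 6.8 percentage points higher from compound 2 to compound 3 (within the scatter) at the ester end, did not do that, so this is the one place among those shown where a single change separates two compounds. The size of this fall is all that can be stated, and nothing measured on these compounds accounts for it.

This single swap alters the chain length and the atoms it carries together, so the compounds shown do not tell which of these matters: a simple amine on a chain of similar length, a longer chain ending in a hydroxyl, or a carboxylic acid in the same place could each help to pull them apart. On these data alone, it also remains open whether 1-hydroxyethyl would behave the same way on the chlorine-bearing core of compound 3.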